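Anilide swap on a chromone acrylamide series

The source may report more compounds than this note shows. Statements on the series, on what has been measured and on what is new or still open speak of the compounds shown alone.

Compound 2 `COc1ccc2c(=O)c(/C=C/C(=O)Nc3ccccc3OC)coc2c1` carries the highest number of the two measured in a functional assay (QGY7701 cells, Homo sapiens) for inhibition, read by MTT assay, with a stated time of 48 h (on this read-out higher numbers stand for weaker inhibition and lower numbers for stronger inhibition), giving 17600 nM. Its nearest neighbour is compound 1 `COc1ccc2c(=O)c(/C=C/C(=O)Nc3ccccc3)coc2c1`, which in this assay gives 14000 nM; the step from the one to the other is a 1.3-fold higher number from compound 1 to compound 2 (0.10 log units; within the scatter). Compound 3 `COc1ccc2c(=O)c(/C=C/C(=O)Nc3ccc(Cl)cc3)coc2c1` is not yet measured. It differs from compound 2 by 4-chlorophenyl in place of 2-methoxyphenyl on an amide-type nitrogen. Within the data shown here, no measured step covers this exchange; the only step available, the addition of a methoxy group on an aromatic carbon, lay within the scatter, so nothing in the data points to a change in either direction. The estimate for compound 3 in this assay is therefore a step of a 1.3-fold lower number from compound 2 to compound 3 (0.10 log units; within the scatter), no larger than the scatter. Compound 3 is expected to give about 14000 nM, with a range from 5000 nM to 35000 nM.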

Compound 3, half-maximal inhibitory concentration: > 100000 nM
Compound 3 was reported as a limit; the forecaster's own chance of this, stated with the estimate: 10%; middle value at least 7.1-fold (0.85 log units) from the limit.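

The value of compound 3 in this assay is a limit and not a number: the limit of > 100000 nM in this assay, at which 1 of the 3 values shown sits. Even so, the aromatic ring on the amide-type nitrogen proves not to be indifferent here, since chloro in place of hydrogen gives an at least 7.1-fold higher number from compound 1 to compound 3 (0.85 log units; beyond the scatter), whereas the methoxy step stayed within the scatter. The exchange of 2-methoxyphenyl for 4-chlorophenyl likewise gives an at least 5.6-fold higher number from compound 2 to compound 3 (0.75 log units; beyond the scatter), so both steps into compound 3 run towards weaker inhibition and both reach beyond the scatter.

On these data alone, the true size of these steps stays open, as does the question of whether the change follows from chloro as such or would also appear with a fluoro group, a nitrile or a carboxylic acid in its place. The three compounds also do not show why the number moves.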